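Swapping phenyl for furan-2-yl on the shared core

The source may report more compounds than this note shows. Statements on the series, on what has been measured and on what is new or still open speak of the compounds shown alone.

Compound 1 `CCOC(=O)c1cnc(NN2C(=O)C=C(C)C2=O)nc1` gives 13000 nM in a functional assay on Jurkat cells (Homo sapiens) for inhibition; on this read-out lower numbers stand for stronger inhibition and higher numbers for weaker inhibition.
Compound 2 `CCOC(=O)c1cnc(NN2C(=O)C=C(C)C2=O)nc1C` gives 1900 nM in this assay.
Compound 3 `CCOC(=O)c1cnc(NN2C(=O)C=C(C)C2=O)nc1-c1ccccc1` gives 1200 nM in this assay.

Among these three, compound 3 shows the lowest number, yet its gap to compound 2 lies within the scatter, so the two cannot be ranked against each other; only compound 1 stands clearly apart. The unmeasured compound 4 `CCOC(=O)c1cnc(NN2C(=O)C=C(C)C2=O)nc1-c1ccco1` differs from compound 3 in one place: furan-2-yl in place of phenyl on an aromatic carbon. For the measured compounds named here, two measured steps bear on this change: an 11-fold lower number from compound 1 to compound 3 (1.03 log units; beyond the scatter) and a 1.6-fold lower number from compound 2 to compound 3 (0.20 log units; within the scatter). Going by the values given here, the first shows that a group in place of hydrogen on this aromatic carbon lowers the number clearly, as compound 2 also shows with a 6.8-fold lower number from compound 1 to compound 2 (0.84 log units; beyond the scatter); the second shows that exchanging methyl for phenyl there adds nothing beyond the scatter. Furan-2-yl is again an aromatic ring at the same place, so the expected change in this assay is small, with no direction beyond the scatter, a 1.3-fold higher number from compound 3 to compound 4 (0.10 log units; within the scatter). Compound 4 is therefore estimated at 1500 nM, within a range from 500 nM to 4500 nM.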

Compound 4, half-maximal inhibitory concentration: 1000 nM
Beside the measured number, compound 4's estimate is 1.5-fold (0.18 log units) above it, and the stated range covers the measured number.
By their numbers in this assay, from the lowest: compounds 4, 3 and 2 (each within the scatter of the next); then compound 1.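

In this assay, phenyl to furan-2-yl is a 1.2-fold lower number from compound 3 to compound 4 (0.08 log units; within the scatter) and methyl to furan-2-yl is a 1.9-fold lower number from compound 2 to compound 4 (0.28 log units; within the scatter) so, both steps being within the scatter, these three groups cannot be told apart on this aromatic carbon. For the compounds shown here, only the step from hydrogen stands clear, at a 13-fold lower number from compound 1 to compound 4 (1.11 log units; beyond the scatter) and this adds something that compound 2 and compound 3 could not show: a five-membered aromatic ring containing oxygen keeps the clear separation from hydrogen just as a six-membered carbon ring and methyl do. Nothing available here explains why these groups read alike.

On these data alone, it remains open whether an amine, a carboxylic acid or a longer alkyl chain on this carbon would read like these three groups or move clearly away from them. Every compound shown also carries the ethoxycarbonyl group, and whether the step from hydrogen would hold with an amide in its place stays open.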